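A few compounds are considered here, and "the series" means these few. Any claim that something is new, unique, unknown or untested is made for them only; others in the source may bear on it.

Measured compounds and their values in a functional assay on COLO 205 cells (Homo sapiens) for inhibition, read by sulforhodamine B assay, with a stated time of 48 h, tested at 50 uM; on this read-out lower numbers stand for less inhibition of growth and higher numbers for more inhibition of growth at the one concentration tested:
compound 1, `COc1cc(/C=C/C(=O)/C=C/c2ccccc2)ccc1OCc1cn(CCCOc2cc(=O)oc3ccccc23)nn1`: 43%
compound 2, `COc1ccccc1/C=C/C(=O)/C=C/c1ccc(OCc2cn(CCCOc3cc(=O)oc4ccccc34)nn2)c(OC)c1`: 57%
compound 3, `COc1ccccc1/C=C/C(=O)/C=C/c1ccc(OCc2cn(CCOc3cc(=O)oc4ccccc34)nn2)c(OC)c1`: 67%

Of the three numbers, compound 3 and compound 2 cannot be told apart, their gap lying within the scatter; compound 1 sits beyond the scatter below compound 3. Among the measured compounds shown here, the one step measured in one place, a number 14 percentage points higher from compound 1 to compound 2 (beyond the scatter), is a methoxy in place of hydrogen on an aromatic carbon of the chain-bound phenyl. Compound 2 and compound 3 differ elsewhere, and their two values stand within the scatter of each other.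

Compound 4, `COc1cc(/C=C/C(=O)/C=C/c2cc(OC)c(OC)c(OC)c2)ccc1OCc1cn(CCOc2cc(=O)oc3ccccc23)nn1`, differs from compound 3 by 3,4,5-trimethoxyphenyl in place of 2-methoxyphenyl on a double-bonded chain carbon bound to a double-bonded chain carbon. For the measured compounds named here, this is again a change in methoxy count on the same phenyl, so the step from compound 1 to compound 2 is the only guide; it was modest and upward, but it added one methoxy on a different position, and no measured pair carries three methoxy groups. The expected step is therefore small, at most modest upward, and plausibly within the scatter: a number 3 percentage points higher from compound 3 to compound 4 (within the scatter). In this assay compound 4 is estimated at 70%, with a range from 52% to 86%.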

Compound 4, percent growth inhibition at one concentration: 86%
For compound 4 the middle estimate is 16 percentage points below the measured one; measured number inside the range.
By their numbers in this assay, from the lowest: compound 1; then compounds 2 and 3 (each within the scatter of the next); then compound 4.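

In this assay, 3,4,5-trimethoxyphenyl in place of 2-methoxyphenyl on a double-bonded chain carbon bound to a double-bonded chain carbon gives a number 19 percentage points higher from compound 3 to compound 4 (beyond the scatter), so this phenyl still responds to change when it already carries a methoxy group. Together with a number 14 percentage points higher from compound 1 to compound 2 (beyond the scatter), that makes two upward steps at this phenyl, though the two pairs differ from each other elsewhere in the structure, and this change alters the number and the placement of methoxy groups at once, so the two cannot be separated. Nothing available accounts for the size of the rise.

From the compounds shown here alone, whether a single methoxy group at another place on this phenyl would match compound 4 at 86% remains open. So does the outcome with an amine or a carboxylic acid on this phenyl in place of the methoxy groups.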